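Swapping a Nitro for a Methyl on a Sulfonyl Aryl

The source may report more compounds than this note shows. Statements on the series, on what has been measured and on what is new or still open speak of the compounds shown alone.

Measured so far in a functional assay on PC-3 cells (Homo sapiens) for cytotoxicity, read by MTT assay, with a stated time of 48 h; on this read-out lower numbers stand for stronger inhibition and higher numbers for weaker inhibition:
compound 1, `CC1=NN(C(=O)CCc2ccccc2)C(c2cc(Br)cc(Br)c2O)C1`: 11300 nM
compound 2, `CC1=NN(S(=O)(=O)c2ccc(C)cc2)C(c2cc(Br)ccc2O)C1`: 33200 nM
compound 3, `CC1=NN(S(=O)(=O)c2ccc([N+](=O)[O-])cc2)C(c2cc(Br)cc(Br)c2O)C1`: 50000 nM

All three compounds share the same core and differ in the group on the ring nitrogen and in the bromine pattern on the phenol. On these numbers compound 3 stands at the highest value, 50000 nM. Its nearest neighbour is compound 2, whose value of 33200 nM lies within the usual scatter of compound 3, so the two cannot be told apart. Compound 1 gives 11300 nM, and this gap from compound 3 lies beyond the scatter.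

Compound 4, `CC1=NN(S(=O)(=O)c2ccc(C)cc2)C(c2cc(Br)cc(Br)c2O)C1`, differs from compound 3 in one place: methyl in place of nitro on an aromatic carbon. Among the measured compounds shown here, no measured pair differs in only one place, so the size of this step has no direct precedent. Compound 2 carries the same methyl-bearing sulfonyl piece as compound 4, with a different bromine pattern. In this assay compound 2 gives 33200 nM. The step from compound 3 to compound 4 is expected to be small, toward a lower number, and probably not beyond the scatter: a 1.7-fold lower number from compound 3 to compound 4 (0.22 log units; within the scatter). For compound 4 the estimate in this assay is 30000 nM, with a range from 12000 nM to 70000 nM.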

Compound 4, half-maximal inhibitory concentration: 51200 nM
Beside the measured number, compound 4's estimate is 1.7-fold (0.23 log units) below it, within the range that was stated.
By their numbers in this assay, from the lowest: compound 1; then compounds 2, 3 and 4 (each within the scatter of the next).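

In this assay, among the compounds shown here, the change from 4-nitrophenyl to 4-methylphenyl gives a 1.0-fold higher number from compound 3 to compound 4 (0.01 log units; within the scatter), the first direct reading at this position, and it shows that these two groups cannot be told apart here even though they share little in atoms or hydrogen-bond acceptors. The second single-place comparison, bromo in place of hydrogen on an aromatic carbon, gives a 1.5-fold higher number from compound 2 to compound 4 (0.19 log units; within the scatter), so this change also leaves no readable mark on the number. Nothing available explains why either exchange leaves the read-out within the usual scatter.

Going by these compounds, whether an amine, a carboxylic acid or a longer chain on the same aromatic carbon, para to a large group, would move the number beyond the scatter remains open. Two groups at one position are too few to show that the position tolerates change in general, and one bromine step on this single sulfonyl background cannot show whether the same exchange would read alike on other groups at the ring nitrogen.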